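A few compounds are considered here, and "the series" means these few. Any claim that something is new, unique, unknown or untested is made for them only; others in the source may bear on it.

In a functional assay on Hep 3B2 cells (Homo sapiens) for cytotoxicity (a higher number here means a weaker inhibitor, a lower number a stronger inhibitor), compound 2 `COc1ccccc1/C=c1\sc2nc(-c3cn(C4CC4)c4cc(N5CCN(C)CC5)c(F)cc4c3=O)nn2c1=O` gives > 10000 nM, which is a limit of the assay and not a number. Compound 1 `Cc1ccc(/C=c2\sc3nc(-c4cn(C5CC5)c5cc(N6CCN(C)CC6)c(F)cc5c4=O)nn3c2=O)cc1` gives > 10000 nM, and this is also a limit. Compound 3 `CN1CCN(c2cc3c(cc2F)c(=O)c(-c2nc4s/c(=C\c5ccc(C#N)cc5)c(=O)n4n2)cn3C2CC2)CC1` has not yet been measured. It keeps the shared core and carries 4-cyanophenyl in place of 2-methoxyphenyl on a double-bonded chain carbon bound to an aromatic carbon. For the measured compounds named here, the only measured step that bears on this change also swaps one substituted phenyl group for another, but it is a step that the two limits leave unreadable from compound 1 to compound 2, so it offers no size to carry over. The nearest guide is the limit of > 10000 nM in this assay, at which 2 of the 2 values shown sit, which gives no reason to expect a change in either direction in this assay. The expected size is therefore no more than the scatter, with an estimated step that the limit leaves unreadable from compound 2 to compound 3. For compound 3 the estimated value is 12000 nM, with an expected range from 3000 nM to 30000 nM.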

Compound 3, half-maximal inhibitory concentration: > 10000 nM
Compound 3 was reported as a limit (the forecaster's own chance of this, stated with the estimate: 65%); the middle value is on the limit's open side.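

No step can be read among compound 1, compound 2 and compound 3, as each result is a limit and not a number: the limit of > 10000 nM in this assay, at which 3 of the 3 values shown sit. The compounds shown leave open how strongly each acts in this assay and whether 4-cyanophenyl or 2-methoxyphenyl makes any difference.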